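The source may hold more compounds than are shown below. What is called first, only, known or untested is meant among the compounds shown, and "the series" means these compounds.

Measured in an ADME assay on Huh-7 cells (Homo sapiens) for cytotoxicity; on this read-out lower numbers stand for higher toxicity in this test and higher numbers for lower toxicity in this test:
- compound 1 `Cc1ccccc1-c1nn(-c2ccccc2Cl)cc1CNCCN1CCN(C)CC1` gives > 20000 nM, which is a limit of the assay.
- compound 2 `Cc1ccccc1-c1nn(-c2ccc(F)cc2F)cc1CNCCN1CCN(C)CC1` gives > 20000 nM, which is a limit of the assay.

Among the compounds with values here, compound 2 stands at the limit, as does the only other value: the limit of > 20000 nM in this assay, at which 2 of the 2 values shown sit. Within the data shown here, the single measured step, a step that the two limits leave unreadable from compound 1 to compound 2, cannot be sized. Compound 3 `Cc1ccccc1-c1nn(-c2ccc(F)cc2F)cc1CN1CCN(C(C)C)CC1` differs from compound 2 by 4-isopropylpiperazin-1-yl in place of (2-(4-methylpiperazin-1-yl)ethyl)amino on a saturated chain carbon bound to an aromatic carbon. Among the measured compounds shown here, no measured step speaks to this exchange. With every value sitting at the limit, compound 3 is expected to remain there as well, an expected step of a number no higher from compound 2 to compound 3 (the limit leaves the size open) in this assay. The estimate for compound 3 is 20000 nM, with a range from 8000 nM to 60000 nM.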

Compound 3, half-maximal cytotoxic concentration: > 20000 nM
Compound 3 was reported as a limit (the forecaster's own chance of this, stated with the estimate: 75%); the middle value sits exactly at the limit.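

No step can be read from compound 2 to compound 3 in this assay, as both values are limits: the limit of > 20000 nM in this assay, at which 3 of the 3 values shown sit. Going by these compounds, the concentration at which compound 1, compound 2 or compound 3 becomes cytotoxic remains open.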